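A few compounds are considered here, and "the series" means these few. Any claim that something is new, unique, unknown or untested is made for them only; others in the source may bear on it.

Measured compounds:
compound 1 `O=C(O)COc1ccc(NC(=O)COc2ccccc2)cc1F` – in a functional assay on CHO cells for agonist activity at Free fatty acid receptor 1 (Homo sapiens), read by FLIPR (a higher number here means that more compound is needed for the effect, a lower number that less compound is needed), compound 1 gives "not determined" (no result reported)
compound 2 `CC(Oc1ccccc1)C(=O)Nc1ccc(OCC(=O)O)c(F)c1` – compound 2 gives 135 nM
compound 3 `CCc1ccc(OCC(=O)Nc2ccc(OCC(=O)O)c(F)c2)cc1` – compound 3 gives "not determined" (no result reported)

Compound 1 therefore stands without a number of its own in this assay, and the same holds for compound 3; the only figure in the set comes from compound 2, which carries a methyl on the carbon between the ether oxygen and the amide carbonyl rather than a change on the aromatic ring. For the measured compounds named here, no pair of measured compounds differing in one place is available, so no measured step can be read off.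

Compound 4 `CC(C)c1cccc(OCC(=O)Nc2ccc(OCC(=O)O)c(F)c2)c1` arises from compound 1 by isopropyl in place of hydrogen on an aromatic carbon. With compound 1 unmeasured, the size of this step cannot be anchored; the expectation is a step of moderate size, more likely toward a larger number in this assay than toward a smaller one, though a result within the scatter of the figure of compound 2 would not be surprising.

For compound 4 the estimated value in this assay is 300 nM, with an expected range from 60 nM to 1500 nM.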

Compound 4, half-maximal effective concentration: 116 nM
Estimate against measurement, compound 4: 2.6-fold (0.41 log units) above; low and high end bracket the measured number.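

For the compounds shown here, compound 1 has no single number in this assay, so no step from it to compound 4 can be read. The compounds shown leave open what isopropyl in place of hydrogen on the aromatic carbon does to the value in this assay. Nothing available bears on the result for compound 4.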